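Swapping the anilino ring substituent in an antiproliferative series

The source may hold more compounds than are shown below. What is called first, only, known or untested is meant among the compounds shown, and "the series" means these compounds.

Compound 1, `O=C(C1=C(Nc2ccccc2)C(=O)N(CCCn2ccnc2)C1c1ccc(Br)cc1)c1ccccc1`: 25700 nM
Compound 2, `Cc1ccc(NC2=C(C(=O)c3ccccc3)C(c3ccc(Br)cc3)N(CCCn3ccnc3)C2=O)cc1`: 24100 nM
Compound 3, `O=C(C1=C(Nc2ccc(Br)cc2)C(=O)N(CCCn2ccnc2)C1c1ccc(Br)cc1)c1ccccc1`: 13000 nM

Of the compounds shown here, three built on one shared core have been tested in a functional assay on U2OS cells (Homo sapiens) for antiproliferative activity, read by MTT assay, with a stated time of 72 h; a higher number here means a weaker inhibitor, a lower number a stronger inhibitor. Compound 1 gives 25700 nM, compound 2 gives 24100 nM and compound 3 gives 13000 nM. Compound 2 holds the second highest number of the three, nearest to compound 1, and the step of a 1.9-fold lower number from compound 2 to compound 3 (0.27 log units; within the scatter) is within the scatter. Since all three numbers lie within the usual scatter of one another, none can be called stronger or weaker than the rest.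

Compound 4, `O=C(C1=C(Nc2ccccc2Br)C(=O)N(CCCn2ccnc2)C1c1ccc(Br)cc1)c1ccccc1`, has not been tested. It differs from compound 2 by 2-bromophenyl in place of 4-methylphenyl on an amine nitrogen. Within the data shown here, two measured steps bear on this change: a 2.0-fold lower number from compound 1 to compound 3 (0.30 log units; within the scatter) and a 1.9-fold lower number from compound 2 to compound 3 (0.27 log units; within the scatter), each bringing a bromo group onto the ring that sits on the amine nitrogen, and each small. Among the measured compounds shown here, in compound 4 the bromine arrives as part of a 2-bromophenyl group, and no measured pair shows that exact change. The step is therefore expected to be small, leaning if anything towards a lower number: a 1.4-fold lower number from compound 2 to compound 4 (0.15 log units; within the scatter). Compound 4 is estimated at 17000 nM in this assay, with a likely range from 7000 nM to 40000 nM.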

Compound 4, half-maximal inhibitory concentration: 16900 nM
Compound 4: middle estimate off by 1.0-fold (0.00 log units), on the high side, within the range that was stated.
By their numbers in this assay, from the lowest: compounds 3, 4, 2 and 1 (each within the scatter of the next).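

With 2-bromophenyl in place of 4-bromophenyl on the amine nitrogen, the step is a 1.3-fold higher number from compound 3 to compound 4 (0.11 log units; within the scatter), so in this assay the place of the bromine on this ring makes no difference that can be told from the scatter. The steps from the two other compounds, a 1.5-fold lower number from compound 1 to compound 4 (0.18 log units; within the scatter) and a 1.4-fold lower number from compound 2 to compound 4 (0.15 log units; within the scatter), also stay inside the scatter, which means that all four ring variants shown at this position are alike in this read-out. No outside evidence bears on this result.

Going by these compounds, what an amine or a carboxylic acid on this ring would do stays open. So does whether any group on the amine nitrogen can move the number beyond the scatter at all.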